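This account rests on a few compounds, and the source may have more. Where it says the series, first, only, none or still open, it means among the compounds named here.

Measured compounds:
compound 1, `Cn1cncc1C(OCc1ccc(C#N)nc1-c1cccc(Cl)c1)c1ccc(C#N)cc1`: 1.8 nM
compound 2, `Cn1cncc1C(OCc1ccc(C#N)cc1-c1cc(Cl)cc(Cl)c1)c1ccc(C#N)nc1`: 3.5 nM
compound 3, `Cn1cncc1C(OCc1ccc(C#N)nc1-c1ccccc1)c1ccc(C#N)cc1`: 19 nM

In a functional assay on NIH3T3 cells (Mus musculus) (on this read-out lower numbers stand for an effect already at smaller amounts and higher numbers for an effect only at larger amounts of compound), compound 3 stands highest of the three numbers, with both gaps to compound 2 and to compound 1 beyond the scatter; compound 1 is the lowest of the set. Compound 4, `Cn1cncc1C(OCc1ccc(C#N)nc1-c1ccc2ccccc2c1)c1ccc(C#N)cc1`, is not yet measured and differs from compound 3 in one place: naphthalen-2-yl in place of phenyl on an aromatic carbon.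

Within the data shown here, the only measured single-point step is an 11-fold higher number from compound 1 to compound 3 (1.02 log units; beyond the scatter), and it concerns a chloro on the aryl group at this aromatic carbon rather than an exchange of the aryl group itself. Among the measured compounds shown here, no measured pair exchanges phenyl for naphthalen-2-yl, so that step bears on the change only indirectly: it shows that what sits on this group moves the number strongly. An expectation of a moderate step toward lower numbers in this assay is therefore taken, with wide uncertainty, and the direction is not secured by any measured pair. Compound 4 is estimated at 8 nM, range 2 nM to 35 nM, which is expected to mean a 2.4-fold lower number from compound 3 to compound 4 (0.38 log units; beyond the scatter).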

Compound 4, half-maximal effective concentration: 7.4 nM
For compound 4 the middle estimate is 1.1-fold (0.03 log units) above the measured one; low and high end bracket the measured number.
By their numbers in this assay, from the lowest: compounds 1 and 2 (each within the scatter of the next); then compound 4; then compound 3.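

In this assay, the earlier chloro step showed only that a substituent on the aryl group matters, whereas this result shows that the aryl group itself can be enlarged at this aromatic carbon, with naphthalen-2-yl in place of phenyl giving a 2.6-fold lower number from compound 3 to compound 4 (0.41 log units; beyond the scatter) and the number moving down. The added ring does not match a single chloro, however: naphthalen-2-yl in place of 3-chlorophenyl gives a 4.1-fold higher number from compound 1 to compound 4 (0.61 log units; beyond the scatter) and the number moves up. The data offered here give no explanation for either step.

On these data alone, it remains open whether a chloro on naphthalen-2-yl would lower the number further, as it does on phenyl. Also open, as far as these compounds go, is how a pyridyl ring, a morpholine or a simple amine would fare at this carbon.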